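Selenol to Methylsulfanyl on a Fused Two-Ring Core

The source may report more compounds than this note shows. Statements on the series, on what has been measured and on what is new or still open speak of the compounds shown alone.

Compound 1 `COc1ccc(CNc2nc([SeH])nc3ccccc23)cc1`: in a functional assay on HT-29 cells (Homo sapiens) for cytotoxicity, read by MTT assay, with a stated time of 72 h (a lower number here means a stronger inhibitor of growth, a higher number a weaker inhibitor of growth), compound 1 gives > 100000 nM, which is a limit of the assay and not a number.
Compound 2 `CSc1nc(NCCCCCO)c2ccccc2n1`: compound 2 gives > 100000 nM, again a limit of the assay.
Compound 3 `[SeH]c1nc([SeH])c2ccccc2n1`: compound 3 gives 45200 nM.

Compound 1 therefore stands at the edge of what this assay can report: no growth-inhibiting concentration was found for it within the tested range, and the same holds for compound 2, since (the limit of > 100000 nM in this assay, at which 2 of the 3 values shown sit). Only compound 3 has a measured number, and that number lies at very weak inhibition.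

Compound 4 `COc1ccc(CNc2nc(SC)nc3ccccc23)cc1` is not yet measured. It differs from compound 1 in one place: a group of 2 heavy atoms (1 carbon, 1 sulfur; no ring) in place of one selenium atom, on an aromatic carbon. For the measured compounds named here, no pair of measured compounds shows this exact change on the shared core, so no measured step can be used as a yardstick. Compound 2, which also carries a methylsulfanyl group on the same core, sits at the limit, and compound 1, which carries the selenium atom, also sits at the limit.

Given those two limits, no shift beyond the usual scatter is expected from compound 1 to compound 4 in this assay, and compound 4 is most likely to return another limit. Compound 4 is estimated at 100000 nM, with a range from 40000 nM to 300000 nM. The expected step is a number no higher from compound 1 to compound 4 (the limit leaves the size open).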

Compound 4, concentration for total growth inhibition: > 100000 nM
Compound 4 was reported as a limit; the forecaster's own chance of this, stated with the estimate: 75%; the middle value sits exactly at the limit.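

In this assay, compound 1 and compound 4 both sit at a limit and not at a number, so no step from one to the other can be read: the limit of > 100000 nM in this assay, at which 3 of the 4 values shown sit.

The compounds shown leave open whether placing methylsulfanyl where the selenium atom stands on the shared core changes growth inhibition at all in this assay.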